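Capping the Amine of Compound 1 with a Carbamate

The compounds below may be only part of what the source reports. "The series", "measured", "known", "first", "only" and "open" are said of these compounds alone.

Measured compounds:
- compound 1, `CCC(C)C(N)c1cc(C(F)(F)F)ccc1N1CCN(C(=O)CCc2ccc(Cl)cc2Cl)CC1`, gives 160 nM
- compound 2, `CC(C)C[C@H](N)c1cc(C(F)(F)F)ccc1N1CCN(C(=O)CCc2csc3ccccc23)CC1`, gives 2300 nM
- compound 3, `Cc1[nH]c2ccccc2c1CCC(=O)N1CCN(c2ccc(C(F)(F)F)cc2[C@@H](N)CC(C)C)CC1`, gives 1600 nM

All three numbers come from an assay on HEK293 cells for displacement of a labelled ligand from Melanocortin receptor 4 (Homo sapiens); on this read-out lower numbers stand for stronger inhibition and higher numbers for weaker inhibition. Compound 1 stands lowest of the three, with compound 3 at a higher number and compound 2 at a still higher number, both gaps beyond the scatter. Among the compounds with values here, the only step between measured compounds, a 1.4-fold lower number from compound 2 to compound 3 (0.16 log units; within the scatter), concerns the ring at the far end of the chain on the carbonyl side and is within the scatter.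

Compound 4, `CCC(C)[C@H](NC(=O)OC)c1cc(C(F)(F)F)ccc1N1CCN(C(=O)CCc2ccc(Cl)cc2Cl)CC1`, differs from compound 1 in a different place: 1-((methoxycarbonyl)amino)-2-methylbutyl in place of 1-amino-2-methylbutyl on an aromatic carbon. Within the data shown here, no measured pair in this set changes this amino group, so the change from compound 1 to compound 4 has no direct precedent here, and the step of a 1.4-fold lower number from compound 2 to compound 3 (0.16 log units; within the scatter) does not bear on it. With no evidence on which to lean, the expectation is only a guess that the capped compound will bind more weakly than compound 1, and the expected step is a 9.4-fold higher number from compound 1 to compound 4 (0.97 log units; beyond the scatter). The estimate for compound 4 in this assay is therefore 1500 nM, within a wide range from 300 nM to 8000 nM.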

Compound 4, inhibition constant: 2400 nM
Estimate against measurement, compound 4: 1.6-fold (0.20 log units) below; measured number inside the range.
By their numbers in this assay, from the lowest: compound 1; then compounds 3, 2 and 4 (each within the scatter of the next).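

Placing 1-((methoxycarbonyl)amino)-2-methylbutyl in place of 1-amino-2-methylbutyl on this aromatic carbon gives, in this assay, a 15-fold higher number from compound 1 to compound 4 (1.18 log units; beyond the scatter), the first direct reading on this amino group. Within the data shown here, the only earlier step, a 1.4-fold lower number from compound 2 to compound 3 (0.16 log units; within the scatter), lies at the ring on the far end of the chain on the carbonyl side, so it says nothing about this position, whereas the new step shows that binding changes strongly when this amine carries a methyl carbamate. Nothing measured here accounts for the size of this rise.

A single capped compound cannot show whether the rise belongs to the methyl carbamate itself or would follow from other changes to this nitrogen, and an acetamide, a urea or an N-methyl amine in the same place would help separate these cases. From the compounds shown here alone, compound 4 also carries a defined stereocentre in this group and compound 1 does not, so the part played by the arrangement at that carbon remains open too.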